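Methoxy in place of phenyl: expectation for compound 4

A few compounds are considered here, and "the series" means these few. Any claim that something is new, unique, unknown or untested is made for them only; others in the source may bear on it.

The three measured compounds share one core and differ in a single group on it. In an assay on mitochondria (strain BALB/c) for inhibition of glycerol-3-phosphate acyltransferase 1, mitochondrial (Mus musculus), read by scintillation counting, with a stated time of 10 min (on this read-out higher numbers stand for weaker inhibition and lower numbers for stronger inhibition), compound 1 `CCCCCCCCS(=O)(=O)Nc1cc(-c2ccccc2Cl)ccc1C(=O)O` gives 26900 nM, compound 2 `CCCCCCCCS(=O)(=O)Nc1cc(-c2ccc(Cl)cc2)ccc1C(=O)O` gives 18100 nM, and compound 3 `CCCCCCCCS(=O)(=O)Nc1cc(-c2ccc(-c3ccccc3)cc2)ccc1C(=O)O` gives 13500 nM. Compound 3 has the lowest of the three numbers, but compound 2 and compound 1 both lie within the scatter of it, so no order among the three can be claimed. The two measured steps say the same: a 1.5-fold lower number from compound 1 to compound 2 (0.17 log units; within the scatter), and a 1.3-fold lower number from compound 2 to compound 3 (0.13 log units; within the scatter).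

Compound 4 `CCCCCCCCS(=O)(=O)Nc1cc(-c2ccc(OC)cc2)ccc1C(=O)O` is compound 3 with methoxy in place of phenyl on an aromatic carbon. The step from compound 2 to compound 3 bears most closely on this change, since it also swapped the group on the same aromatic carbon and stayed within the scatter; the step from compound 1 to compound 2 likewise stayed within the scatter. Going by the values given here, no measured compound carries a methoxy, so no direction can be read from the numbers. The expectation for this assay is therefore no step beyond the scatter. Compound 4 is expected to give about 18000 nM, with a range from 8000 nM to 40000 nM, which corresponds to an expected step of a 1.3-fold higher number from compound 3 to compound 4 (0.12 log units; within the scatter).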

Compound 4, half-maximal inhibitory concentration: 13300 nM
For compound 4 the middle estimate is 1.4-fold (0.13 log units) above the measured one; low and high end bracket the measured number.
By their numbers in this assay, from the lowest: compounds 4, 3, 2 and 1 (each within the scatter of the next, the first and the last beyond it).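

In this assay, the aromatic carbon para to a large group takes methoxy in place of phenyl with a 1.0-fold lower number from compound 3 to compound 4 (0.01 log units; within the scatter), so losing the six-membered aromatic ring and gaining a hydrogen-bond acceptor, with four fewer heavy atoms, produces no readable change. Methoxy also stays level with chloro at this place, with a 1.4-fold lower number from compound 2 to compound 4 (0.13 log units; within the scatter), which means that phenyl, chloro and methoxy cannot be told apart here, although they differ widely in size. Going by these compounds alone, the first step beyond the scatter is modest, with a 2.0-fold lower number from compound 1 to compound 4 (0.31 log units; beyond the scatter), and it puts 4-methoxyphenyl in place of 2-chlorophenyl, so it does not rest on the methoxy group alone.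

Going by these compounds, whether an amine or a carboxylic acid at this place would move the number beyond the scatter remains open, as does whether any group here can do more than the small differences seen so far. Nothing available explains why these three groups read alike.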